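From 2-cyanophenyl to 2,3-dichlorophenyl on a shared core

This account rests on a few compounds, and the source may have more. Where it says the series, first, only, none or still open, it means among the compounds named here.

- compound 1 `COC(=O)C1=C(C)N=C(C)/C(=C(\O)OC)C1c1ccc(F)cc1` gives 129 nM
- compound 2 `COC(=O)C1=C(C)N=C(C)/C(=C(\O)OC)C1c1ccccc1C#N` gives 15.9 nM
- compound 3 `COC(=O)C1=C(C)N=C(C)/C(=C(\O)OC)C1c1cccc(Cl)c1Cl` is not yet measured

These values come from a functional assay (muscle tissue) with Cavia porcellus as the target; on this read-out higher numbers stand for an effect only at larger amounts of compound and lower numbers for an effect already at smaller amounts. Compound 2 stands lowest of the two measured compounds. Compound 3 shares its core and carries 2,3-dichlorophenyl in place of 2-cyanophenyl on a saturated ring carbon.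

For the measured compounds named here, only one measured step bears on this change, since it altered the group at the same place: an 8.1-fold lower number from compound 1 to compound 2 (0.91 log units; beyond the scatter). That step shows that exchanging this group can move the number well beyond the scatter. The 2,3-dichlorophenyl group itself has no measured value on this core, so the direction remains uncertain. A smaller step than that one is expected, leaning slightly lower and possibly not beyond the scatter. The estimated step is a 1.6-fold lower number from compound 2 to compound 3 (0.20 log units; within the scatter). Compound 3 is expected at 10 nM, with an estimated range from 2.5 nM to 40 nM.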

Compound 3, half-maximal effective concentration: 19.1 nM
Estimate against measurement, compound 3: 1.9-fold (0.28 log units) below; the range from low to high includes it.
By their numbers in this assay, from the lowest: compounds 2 and 3 (each within the scatter of the next); then compound 1.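

In this assay, the change of 2-cyanophenyl to 2,3-dichlorophenyl on the saturated ring carbon gives a 1.2-fold higher number from compound 2 to compound 3 (0.08 log units; within the scatter). A low number at this position therefore does not depend on the nitrile or on the hydrogen-bond acceptor counted in 2-cyanophenyl, since 2,3-dichlorophenyl has neither, and a 6.8-fold lower number from compound 1 to compound 3 (0.83 log units; beyond the scatter) shows that this group also stands apart from 4-fluorophenyl. No available evidence bears on why the two groups read alike.

The compounds shown leave open how an unsubstituted phenyl group, or a phenyl group carrying an amine or a carboxylic acid, would read at this position. They also leave open whether the link between these groups and the number would hold with a longer chain in place of the methoxycarbonyl group.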